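Series notes: hexyl extension from compound 3 to compound 4

The source may report more compounds than this note shows. Statements on the series, on what has been measured and on what is new or still open speak of the compounds shown alone.

Going by the values given here, in a functional assay on MCF7 cells (Homo sapiens) for cytotoxicity, read by MTT assay, with a stated time of 72 h (on this read-out higher numbers stand for weaker inhibition and lower numbers for stronger inhibition), compound 1 `O=C(CSC(=S)N[C@H]1CCOC1=O)Nc1ccccc1Cl` gives 90800 nM and compound 2 `O=C(CSC(=S)N[C@H]1CCOC1=O)Nc1ccc(F)cc1` gives 5830 nM; the step of a 16-fold lower number from compound 1 to compound 2 (1.19 log units; beyond the scatter) is the only measured step beyond the scatter. Compound 3 `CCSC(=S)N[C@H]1CCOC1=O` returns in this assay only the limit > 128000 nM, a limit and not a number, so it stands at the weak end of what has been measured, as marked by the limit of > 128000 nM in this assay, at which 1 of the 3 values shown sits. Compound 4 `CCCCCCCCSC(=S)N[C@H]1CCOC1=O` differs from compound 3 by hexyl in place of hydrogen on a saturated chain carbon, two bonds along the chain from a sulfur. Among the compounds with values here, no measured step bears on this change: the one known step concerns the aryl group on the amide-type nitrogen, not the saturated chain, so the expectation rests on little. A step of an at least 2.3-fold lower number from compound 3 to compound 4 (0.36 log units; beyond the scatter) toward a lower number is expected, with a real chance that compound 4 again returns only a limit. Compound 4 is estimated at 55000 nM, range 15000 nM to 200000 nM.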

Compound 4, half-maximal inhibitory concentration: > 128000 nM
Compound 4: no number, only a limit; the forecaster's own chance of this, stated with the estimate: 40%; at least 2.3-fold (0.36 log units) between middle value and limit.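

Compound 3 and compound 4 both return only limits in this assay, so no step can be read between them: the limit of > 128000 nM in this assay, at which 2 of the 4 values shown sit.

On these data alone, whether hexyl in place of hydrogen on the saturated chain changes cytotoxicity at all remains open.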